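From pyrimidin-2-yl to pyridin-3-yl on compound 1

The source may report more compounds than this note shows. Statements on the series, on what has been measured and on what is new or still open speak of the compounds shown alone.

In an ADME assay on LLC-MK2 cells (Macaca mulatta) for cytotoxicity, read by spectrophotometry and crystal violet staining, with a stated time of 4 days (on this read-out lower numbers stand for higher toxicity in this test and higher numbers for lower toxicity in this test), compound 1 (`CC(C)n1ncc2c(C(=O)Nc3ncccn3)cc(-c3ccsc3)nc21`) gives 50000 nM. Compound 2 (`CC(C)n1ncc2c(C(=O)Nc3ncccn3)cc(-c3cccs3)nc21`) gives 75000 nM, and compound 3 (`CC(C)n1ncc2c(C(=O)Nc3cc(C(N)=O)ccc3F)cc(-c3cccs3)nc21`) gives 25000 nM. Compound 1 therefore holds the middle of the three numbers, within the scatter of both others.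

Compound 4 (`CC(C)n1ncc2c(C(=O)Nc3cccnc3)cc(-c3ccsc3)nc21`) keeps the rest of compound 1 but carries pyridin-3-yl in place of pyrimidin-2-yl on an amide-type nitrogen.

Two measured steps are available. The first, with thiophen-2-yl in place of thiophen-3-yl, is a 1.5-fold higher number from compound 1 to compound 2 (0.18 log units; within the scatter). It leaves the amide-type nitrogen untouched and so says little here. The second is a 3.0-fold lower number from compound 2 to compound 3 (0.48 log units; beyond the scatter), with 5-carbamoyl-2-fluorophenyl in place of pyrimidin-2-yl at the same place. Going by the values given here, it is the only measured change there, and it is only a loose guide, since the group that enters differs from pyridin-3-yl. Among the compounds with values here, no measurement yet shows what pyridin-3-yl itself does. A small move towards a lower number is therefore expected, smaller than that second step and probably within the scatter. The expected change is a 1.3-fold lower number from compound 1 to compound 4 (0.10 log units; within the scatter). Compound 4 is expected at 40000 nM, with an estimated range from 15000 nM to 100000 nM.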

Compound 4, half-maximal cytotoxic concentration: 37000 nM
Estimate against measurement, compound 4: 1.1-fold (0.03 log units) above; the range from low to high includes it.
By their numbers in this assay, from the lowest: compounds 3, 4, 1 and 2 (each within the scatter of the next, the first and the last beyond it).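

Pyridin-3-yl in place of pyrimidin-2-yl on the amide-type nitrogen gives a 1.4-fold lower number from compound 1 to compound 4 (0.13 log units; within the scatter) in this assay, so this read-out does not separate the two compounds, even though the entering ring has 1 hetero atom and 1 hydrogen-bond acceptor where the leaving ring has 2 of each. Going by these compounds alone, until now the only measured change at this place was a 3.0-fold lower number from compound 2 to compound 3 (0.48 log units; beyond the scatter), which brought in 5-carbamoyl-2-fluorophenyl on the thiophen-2-yl compound and lay beyond the scatter, whereas the six-membered aromatic ring now tested on the thiophen-3-yl compound, with the same 6 heavy atoms as the one it replaces, stays within it. No measurement shown here explains either outcome at this place.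

The compounds shown leave open what a plain phenyl ring, or pyridin-2-yl or pyridin-4-yl, would do on this amide-type nitrogen. They also leave open whether a carbamoyl group or a fluorine alone accounts for the step seen with 5-carbamoyl-2-fluorophenyl, and whether pyridin-3-yl behaves the same way alongside thiophen-2-yl.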